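The compounds below may be only part of what the source reports. "The series", "measured", "known", "first", "only" and "open" are said of these compounds alone.

Compound 3, `Cc1ccc(C)c(NS(=O)(=O)c2cccc(CCCCCCNC(=O)/C=C/c3cccnc3)c2)c1`, is examined in an assay on isolated protein for inhibition of Nicotinamide phosphoribosyltransferase (Homo sapiens), read by WST assay, with stated times of 60 min, 5 min and 30 min, in the presence of a further agent that is not named here; a lower number here means a stronger inhibitor, a higher number a weaker inhibitor. Against the other two compounds that have been measured, compound 3 gives 11.6 nM, the lowest number of the three. Compound 2, `O=C(/C=C/c1cccnc1)NCCCCCc1cccc(S(=O)(=O)Nc2ccccc2)c1`, comes nearest, giving 16.5 nM, a number that lies within the usual scatter of compound 3, so the two cannot be told apart. Compound 1, `O=C(/C=C/c1cccnc1)NCCCc1cccc(S(=O)(=O)Nc2ccccc2)c1`, stands furthest away and gives 235 nM, a gap from compound 3 that lies well beyond the scatter; compound 1 differs from compound 2 in the length of the chain and is not a single-change neighbour of compound 3.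

Compound 4, `O=C(/C=C/c1cccnc1)NCCCCCCc1cccc(S(=O)(=O)Nc2ccc(F)c(Cl)c2)c1`, has not yet been measured. It differs from compound 3 in one place: 3-chloro-4-fluorophenyl in place of 2,5-dimethylphenyl on a sulfonamide nitrogen. The six-membered chain and the rest of the shared core stay as in compound 3. For the measured compounds named here, no pair of measured compounds shows what a change on this part of the molecule does, so there is nothing here to set its direction or size. The expectation is therefore a step from compound 3 to compound 4 of about a 1.0-fold higher number from compound 3 to compound 4 (0.01 log units; within the scatter), not beyond the scatter. On that basis compound 4 is estimated to give 12 nM in this assay, with a range from 4 nM to 40 nM.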

Compound 4, half-maximal inhibitory concentration: 9.7 nM
Estimate against measurement, compound 4: 1.2-fold (0.09 log units) above; measured number inside the range.
By their numbers in this assay, from the lowest: compounds 4, 3 and 2 (each within the scatter of the next); then compound 1.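

On the sulfonamide nitrogen, putting 3-chloro-4-fluorophenyl in place of 2,5-dimethylphenyl gives, in this assay, a 1.2-fold lower number from compound 3 to compound 4 (0.08 log units; within the scatter), a step within the scatter, so the two compounds cannot be told apart. For the compounds shown here, this is the first single-place comparison at this position, and it shows that one aromatic ring of carbon with two methyl groups can give way to one bearing chlorine and fluorine, with the same count of heavy atoms, and no step beyond the scatter follows. What this one pair cannot show is how far that tolerance extends to other groups at this position, and nothing available accounts for the result.

Going by these compounds, whether this position would stay as undemanding with a group of a different kind on the ring, such as an amine or a carboxylic acid, or with a pyridine ring in place of the phenyl ring, remains open. Also open, on these data alone, is whether the same exchange would give a similarly small step on a shorter chain, as in compound 1, or on a longer chain than the six-membered one shared by compound 3 and compound 4.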